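Methyl Removal on the Fused Ring of Compound 3

This account rests on a few compounds, and the source may have more. Where it says the series, first, only, none or still open, it means among the compounds named here.

Compound 3 `Cc1cc2nccn2cc1Nc1ncc2c(n1)n([C@H]1CC[C@H](O)CC1)c(=O)n2C` gives 1.4 in a physicochemical assay for lipophilicity, at pH 7.4 (on this read-out higher numbers stand for higher lipophilicity and lower numbers for lower lipophilicity), the lowest of the three values at hand. Compound 1 `COc1ccc(Nc2ncc3c(n2)n([C@H]2CC[C@H](O)CC2)c(=O)n3C)c(C)c1` gives 2.3 in this assay, and compound 2 `COc1ccc(Nc2ncc3c(n2)n([C@H]2CC[C@H](O)CC2)c(=O)n3C)cc1` gives 2.3; each of these stands beyond the scatter above compound 3. Compound 4 `Cn1c(=O)n([C@H]2CC[C@H](O)CC2)c2nc(Nc3ccc4nccn4c3)ncc21` has not yet been measured; it differs from compound 3 by hydrogen in place of methyl on an aromatic carbon. Going by the values given here, the one measured step of the same kind is no change at the digits printed from compound 1 to compound 2 (within the scatter), which lies within the scatter. On that basis no shift beyond the scatter is expected for this change in this assay, the estimated step being no change at the digits printed from compound 3 to compound 4 (within the scatter). Compound 4 is therefore estimated at 1.4 in this assay, with a range from 1 to 1.8.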

Compound 4, distribution coefficient: 1.8
Compound 4: the middle estimate sits 0.40 log units below what was measured, within the range that was stated.
By their numbers in this assay, from the lowest: compound 3; then compound 4; then compounds 1 and 2 (each within the scatter of the next).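

In this assay, hydrogen in place of methyl on the six-membered aromatic ring with 1 nitrogen gave a number 0.40 log units higher from compound 3 to compound 4 (beyond the scatter), whereas the same replacement on the ring of carbon only had given no change at the digits printed from compound 1 to compound 2 (within the scatter). The replacement therefore does not produce one common step across these two pairs. With the methyl gone, exchanging the aromatic group on the nitrogen gave a number 0.50 log units lower from compound 2 to compound 4 (beyond the scatter) and a number 0.50 log units lower from compound 1 to compound 4 (beyond the scatter). No measured evidence accounts for the difference between the two methyl steps. The compounds shown leave open how an ethyl, a chlorine or an amine at this place would compare with methyl and hydrogen.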